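This account rests on a few compounds, and the source may have more. Where it says the series, first, only, none or still open, it means among the compounds named here.

The series shares the core of compound 1 `C#Cc1cn([C@@H]2O[C@H](CO)[C@@H](O)[C@H]2O)c2ncnc(C)c12`, with two sites of variation. In a functional assay on K562 cells (Homo sapiens), read by MTT assay, with a stated time of 72 h (a lower number here means a stronger inhibitor, a higher number a weaker inhibitor), compound 1 gives 110 nM, the lowest of the two numbers in hand. Within the data shown here, compound 3 `C#Cc1cn([C@@H]2O[C@H](CO)[C@@H](O)[C@H]2O)c2ncnc(N(C)C)c12` gives 260 nM in this assay; the step of a 2.4-fold higher number from compound 1 to compound 3 (0.37 log units; beyond the scatter) is the only single-point change measured so far, and it is made at a different site from the one varied here. Compound 2 `CSc1ncnc2c1c(-c1ccccc1)cn2[C@@H]1O[C@H](CO)[C@@H](O)[C@H]1O` differs from compound 1 in two places, a phenyl in place of the ethynyl and a methylthio in place of the methyl. In this assay compound 2 gives only a limit, > 20000 nM, in line with the limit of > 20000 nM in this assay, at which 1 of the 3 values shown sits. Compound 4 `Cc1ncnc2c1c(-c1ccoc1)cn2[C@@H]1O[C@H](CO)[C@@H](O)[C@H]1O` is not yet measured; it keeps the methyl of compound 1 and carries furan-3-yl in place of ethynyl on an aromatic carbon. Among the measured compounds shown here, no measured step follows this exchange directly. For the measured compounds named here, the only pointer is compound 2, where the one aromatic ring that has so far stood at this site, the phenyl, came with a limit rather than a number, though the methylthio change is confounded with it. A weaker number is therefore expected for compound 4, with wide uncertainty: the estimated step is a 14-fold higher number from compound 1 to compound 4 (1.13 log units; beyond the scatter). For compound 4 the expected value in this assay is 1500 nM, with a range from 200 nM to 15000 nM.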

Compound 4, half-maximal inhibitory concentration: > 20000 nM
Compound 4 ended at the assay's limit; the forecaster's own chance of this, stated with the estimate: 15%; at least 13-fold (1.12 log units) between middle value and limit.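

With the methyl of compound 1 kept, furan-3-yl in place of ethynyl is a change in one place, and it gives an at least 180-fold higher number from compound 1 to compound 4 (2.25 log units; beyond the scatter); the figure is a bound, since compound 4 reaches a limit and yields no number. The limit seen with compound 2 could not be assigned to the phenyl alone. The methylthio changed with it. Compound 4 shows that exchanging the ethynyl at this position for an aromatic ring is enough by itself to reach the limit in this assay. Among the compounds shown, the two with ethynyl at this position give numbers and the two with an aromatic ring do not, which places compound 2 and compound 4 at the ceiling of the read-out: the limit of > 20000 nM in this assay, at which 2 of the 4 values shown sit.

The compounds shown do not separate the loss of the ethynyl from the arrival of a ring, so it stays open whether a nitrile, a vinyl or a propynyl chain at this position would keep a measurable number in this assay. Going by these compounds, how far the other site can be varied with ethynyl held also stays open, beyond the dimethylamino group, where the record is a 2.4-fold higher number from compound 1 to compound 3 (0.37 log units; beyond the scatter).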